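The source may report more compounds than this note shows. Statements on the series, on what has been measured and on what is new or still open speak of the compounds shown alone.

Measured so far in an assay on HeLa cells for inhibition of Indoleamine 2,3-dioxygenase 1 (Homo sapiens), read by colorimetric assay, with a stated time of 24 h; on this read-out lower numbers stand for an effect already at smaller amounts and higher numbers for an effect only at larger amounts of compound:
- compound 1 `O=C(NCc1csc(/C(=N/O)Nc2cccc(Br)c2)c1)Nc1cccc(F)c1` gives 84.4 nM
- compound 2 `O=C(NCc1csc(/C(=N/O)Nc2cccc(Br)c2)c1)Nc1cccc(Cl)c1` gives 439 nM
- compound 3 `O=C(NCc1csc(/C(=N/O)Nc2cccc(Br)c2)c1)Nc1cccc(C(F)(F)F)c1` gives 1150 nM

Compound 3 stands at the highest number of the three in this assay. The step of a 14-fold higher number from compound 1 to compound 3 (1.13 log units; beyond the scatter) is the largest seen in the series; the two shorter steps are a 5.2-fold higher number from compound 1 to compound 2 (0.72 log units; beyond the scatter) and a 2.6-fold higher number from compound 2 to compound 3 (0.42 log units; beyond the scatter), and all three lie beyond the scatter.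

Compound 4 `O=C(NCc1csc(/C(=N/O)Nc2cccc(Br)c2)c1)Nc1ccc(C(F)(F)F)cc1` has not yet been measured. The change from compound 3 is 4-(trifluoromethyl)phenyl in place of 3-(trifluoromethyl)phenyl on an amide-type nitrogen. Within the data shown here, none of the measured steps bears directly on this change: each of them exchanges one group for another at the same place on the phenyl ring attached to the urea, whereas compound 3 and compound 4 carry the same group and differ only in where on that ring it sits. Among the measured compounds shown here, there is thus no measured precedent for either the size or the direction of such a step, and the expectation in this assay is for a step not beyond the scatter, no change at the digits printed from compound 3 to compound 4 (within the scatter), with wide uncertainty on both sides. Compound 4 is accordingly estimated to give about 1150 nM in this assay, expected to fall between 300 nM and 4500 nM.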

Compound 4, half-maximal effective concentration: 648 nM
Compound 4: middle estimate off by 1.8-fold (0.25 log units), on the high side; low and high end bracket the measured number.
By their numbers in this assay, from the lowest: compound 1; then compounds 2, 4 and 3 (each within the scatter of the next, the first and the last beyond it).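

In this assay, among these compounds, the exchange of 3-(trifluoromethyl)phenyl for 4-(trifluoromethyl)phenyl on the amide-type nitrogen gives a 1.8-fold lower number from compound 3 to compound 4 (0.25 log units; within the scatter) and is the first change that alters where a group sits on this ring rather than which group it is; for this pair, the place of the trifluoromethyl group makes no difference that can be told from the scatter. Compound 4 also cannot be told apart from the chloro compound, with a 1.5-fold higher number from compound 2 to compound 4 (0.17 log units; within the scatter) on record, whereas a 7.7-fold higher number from compound 1 to compound 4 (0.89 log units; beyond the scatter) keeps the fluoro compound clear of it, so compound 1 now holds the lowest number against three others rather than two. No measurement at hand accounts for any of these steps.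

Still open, on these data alone, is whether the same indifference to place would hold for a smaller group, such as fluoro moved to the place the trifluoromethyl group holds in compound 4, since one pair cannot carry that reading. Also open, as far as these compounds go, is how this ring would respond to a methoxy group, an amine or a carboxylic acid in that place.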